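Methoxy in Place of Dimethylamino on Two Related Cores

The source may report more compounds than this note shows. Statements on the series, on what has been measured and on what is new or still open speak of the compounds shown alone.

Compound 1 `COC(=O)c1cccc(Oc2ccc(N(C)C)cc2)c1` was tested in a functional assay on HL-60 cells (Homo sapiens) for antiproliferative activity (on this read-out lower numbers stand for stronger inhibition and higher numbers for weaker inhibition), and gives only a limit of the assay, > 20000 nM. Compound 2 `COC(=O)c1cccc(Oc2ccc(OC)cc2)c1` likewise gives in this assay only a limit of the assay, > 20000 nM. The change between these two is methoxy in place of dimethylamino on an aromatic carbon and the step it made is a step that the two limits leave unreadable from compound 1 to compound 2, which rests on the limit of > 20000 nM in this assay, at which 2 of the 3 values shown sit, and therefore cannot be read as either a gain or a loss.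

Compound 3 `CCOC(=O)c1ccc(Oc2ccc(N(C)C)cc2)cc1O` carries a different core; the difference between its core and that of compound 1 is not broken down here. In this assay compound 3 gives only a limit of the assay, > 30000 nM, as the limit of > 30000 nM in this assay, at which 1 of the 3 values shown sits, records. Compound 4 `CCOC(=O)c1ccc(Oc2ccc(OC)cc2)cc1O` has not been measured in this assay; it differs from compound 3 by methoxy in place of dimethylamino on an aromatic carbon, the same change as that from compound 1 to compound 2, made at a place described in the same words.

Among the measured compounds shown here, since every measured value shown sits at a limit of this assay, and the one earlier instance of this change gave a step that the two limits leave unreadable from compound 1 to compound 2, the step expected from compound 3 to compound 4 is estimated as a number no higher from compound 3 to compound 4 (the limit leaves the size open), with no readable direction behind it. Compound 4 is therefore expected to give in this assay about 30000 nM, with an estimated range from 10000 nM to 100000 nM, most likely reported again only as a limit.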

Compound 4, half-maximal inhibitory concentration: > 30000 nM
Compound 4 was reported as a limit; the forecaster's own chance of this, stated with the estimate: 85%; the middle value lies on the limit itself.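

In this assay compound 4 gives only a limit of the assay, > 30000 nM. Compound 3 also stands at a limit, so no step can be read from compound 3 to compound 4, and none from compound 1 to compound 2 either. The compounds shown leave open whether methoxy in place of dimethylamino on an aromatic carbon changes the read-out in this assay at all.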